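Ring Swap Repeated on a Second Amide Scaffold

This account rests on a few compounds, and the source may have more. Where it says the series, first, only, none or still open, it means among the compounds named here.

The compounds here were tested in a functional assay on BXPC-3 cells (Homo sapiens) for inhibition, read by MTT assay, with a stated time of 72 h; on this read-out higher numbers stand for weaker inhibition and lower numbers for stronger inhibition. Compound 1, `Cc1cnc(C(=O)Nc2cc(F)cc3cccnc23)cn1`, gives in this assay > 10000 nM, which is a limit of the assay rather than a number. Compound 2, `O=C(Nc1cc(F)cc2cccnc12)c1ncccn1`, gives in this assay > 10000 nM, again a limit and not a number. The change from compound 1 to compound 2 is pyrimidin-2-yl in place of 5-methylpyrazin-2-yl on a carbonyl carbon, and the step is a step that the two limits leave unreadable from compound 1 to compound 2; its size cannot be read because of the limit of > 10000 nM in this assay, at which 2 of the 3 values shown sit.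

Among the compounds with values here, compound 3, `Cc1cnc(C(=O)Nc2cc(OCCNC(=O)OC(C)(C)C)cc3cccnc23)cn1`, is the one compound with a number: in this assay compound 3 gives 3670 nM. The difference between the core of compound 3 and the core of compound 1 is not broken down here.

Compound 4, `CC(C)(C)OC(=O)NCCOc1cc(NC(=O)c2ncccn2)c2ncccc2c1`, has not yet been measured. It differs from compound 3 by pyrimidin-2-yl in place of 5-methylpyrazin-2-yl on a carbonyl carbon, the same change as that between compound 1 and compound 2, at the same place. Since the earlier step is unreadable, no size for this change can be taken from it, so the expectation for compound 4 rests only on the value of compound 3 together with the widely spread possibilities. Compound 4 is expected to give about 5000 nM, a step of a 1.4-fold higher number from compound 3 to compound 4 (0.13 log units; within the scatter) that is estimated to lie between 1500 nM and 20000 nM, with a real chance that only a limit is reported.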

Compound 4, half-maximal inhibitory concentration: > 10000 nM
Compound 4: only a limit was reported; the forecaster's own chance of this, stated with the estimate: 35%; middle value at least 2.0-fold (0.30 log units) from the limit.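

In this assay, putting pyrimidin-2-yl in place of 5-methylpyrazin-2-yl on the carbonyl carbon gives an at least 2.7-fold higher number from compound 3 to compound 4 (0.43 log units; beyond the scatter), so on this core the swap comes with weaker inhibition, and by more than repeat measurements would normally scatter. On these data alone, the same swap from compound 1 to compound 2 cannot be read, and the full size of the step to compound 4 also stays unknown, because the values run into the ceiling of the assay: the limit of > 10000 nM in this assay, at which 3 of the 4 values shown sit. This leaves one readable step on one core, which shows that the swap can cost activity but does not show that it does so on the core of compound 1, nor whether the loss comes from the missing methyl or from the changed ring.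

A pyrazin-2-yl group without the methyl would be needed to separate those two parts of the change, and the compounds shown do not include one. Also open, as far as these compounds go, is how the swap behaves when the side chain of compound 3 ends in a free amine or a carboxylic acid rather than a tert-butyl carbamate, or when that chain is longer.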